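Piperidin-1-yl for fluoro: an expected permeability

The source may report more compounds than this note shows. Statements on the series, on what has been measured and on what is new or still open speak of the compounds shown alone.

compound 1 `O=C(Nc1ccc(F)c(Cl)c1)c1cc(Cl)ccc1O` gives 11.5 10^-6 cm/s
compound 2 `O=C(Nc1ccc(F)cc1)c1cc(Cl)ccc1O` gives 18.2 10^-6 cm/s
compound 3 `O=C(Nc1ccc(N2CCCCC2)cc1)c1cc(Cl)ccc1O` is not yet measured

Both numbers come from an ADME assay for permeability, using PAMPA, with a stated time of 3 h (on this read-out higher numbers stand for higher permeability and lower numbers for lower permeability), as their common read-out. Among the compounds with values here, compound 2 at 18.2 10^-6 cm/s lies within the scatter of compound 1, its only measured neighbour. Going on to compound 3 brings one change (piperidin-1-yl in place of fluoro on an aromatic carbon) with piperidin-1-yl in place of fluoro on an aromatic carbon. Within the data shown here, the one measured step (a 1.6-fold higher number from compound 1 to compound 2 (0.20 log units; within the scatter)) stayed within the scatter, but it is a different change, hydrogen in place of chloro, and bears only weakly here. No step beyond the scatter is therefore expected in this assay on this thin evidence. The estimated step (a 1.5-fold lower number from compound 2 to compound 3 (0.18 log units; within the scatter)) fits that expectation. Compound 3 is estimated at 12 10^-6 cm/s (expected range 4 10^-6 cm/s to 30 10^-6 cm/s).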

Compound 3, apparent permeability: 43.3 10^-6 cm/s
Beside the measured number, compound 3's estimate is 3.6-fold (0.56 log units) below it, and the stated range ends below it.
By their numbers in this assay, from the lowest: compounds 1 and 2 (each within the scatter of the next); then compound 3.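

In this assay, piperidin-1-yl in place of fluoro on this aromatic carbon brings a 2.4-fold higher number from compound 2 to compound 3 (0.38 log units; beyond the scatter), the only step shown that lies beyond the scatter. The position therefore takes a larger group carrying a non-aromatic ring and a hydrogen-bond acceptor, and the number rises rather than falls. Nothing measured here accounts for this step.

Going by these compounds, whether the step follows the ring or the nitrogen on the aromatic carbon stays open; a morpholine, a dimethylamino group or a cyclohexyl group here would separate them. On these data alone, whether the same change holds alongside the extra chloro of compound 1 also remains open.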